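The compounds below may be only part of what the source reports. "The series", "measured", "known", "first", "only" and "open" are said of these compounds alone.

Compound 1 `c1ccc(C2CCCCN2C2CCN(CCCc3c[nH]c4ccc(-n5cnnc5)cc34)CC2)cc1`: 1.9 nM
Compound 2 `CC(C)=CCCN(C)C1CCN(CCCc2c[nH]c3ccc(-n4cnnc4)cc23)CC1`: 2.6 nM

Both values come from an assay on CHO cells for displacement of a labelled ligand from 5-hydroxytryptamine receptor 1D (Homo sapiens); on this read-out higher numbers stand for weaker inhibition and lower numbers for stronger inhibition. Compound 2 stands close to compound 1; the gap between them lies within the usual scatter, so neither can be set above the other. Compound 3 `C[C@H](NCC1CCN(CCCc2c[nH]c3ccc(-n4cnnc4)cc23)CC1)c1ccccc1` awaits measurement in this assay. It differs from compound 2 by ((1-phenylethyl)amino)methyl in place of methyl(4-methylpent-3-en-1-yl)amino on a saturated ring carbon. Going by the values given here, no step between measured compounds is available to size this change. Compound 3 is expected to stay potent, with an estimated 3 nM (range 1 nM to 12 nM), because compound 2 gives 2.6 nM on the same shared core. The step of a 1.2-fold higher number from compound 2 to compound 3 (0.06 log units; within the scatter) is expected to be none beyond the scatter.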

Compound 3, half-maximal inhibitory concentration: 4.4 nM
Compound 3: middle estimate off by 1.5-fold (0.17 log units), on the low side, within the range that was stated.
By their numbers in this assay, from the lowest: compounds 1, 2 and 3 (each within the scatter of the next, the first and the last beyond it).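

In this assay, putting ((1-phenylethyl)amino)methyl in place of methyl(4-methylpent-3-en-1-yl)amino on this saturated ring carbon gives a 1.7-fold higher number from compound 2 to compound 3 (0.23 log units; within the scatter) and so shows that this position accepts a change of this size with no shift beyond the scatter. The entering group brings a six-membered aromatic ring, a hydrogen-bond donor and a defined stereocentre, which the leaving group lacks. Nothing available explains this result. The compounds shown leave open how the opposite stereoisomer would read, and whether a plain aminomethyl or a carboxylic acid would hold at this carbon.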